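A few compounds are considered here, and "the series" means these few. Any claim that something is new, unique, unknown or untested is made for them only; others in the source may bear on it.

Measured compounds in an ADME assay on RAW264.7 cells (Mus musculus) for cytotoxicity, read by MTT assay, with a stated time of 48 h, tested at 50 uM; a higher number here means more inhibition at the concentration tested (going by the name of the read-out), a lower number less inhibition:
compound 1 `NC(=O)c1c(NC(=O)c2ccc(Oc3ccccc3)cc2)sc2c1CCN(C(=O)c1ccccc1)C2` gives 4.71%
compound 2 `CC(=O)N1CCc2c(sc(NC(=O)c3ccc(Oc4ccccc4)cc3)c2C(N)=O)C1` gives 32.9%
compound 3 `CC(C)(C)OC(=O)N1CCc2c(sc(NC(=O)c3ccc(Oc4ccccc4)cc3)c2C(N)=O)C1` gives 26.9%

Compound 3 stands second highest of the three numbers: its value sits near that of compound 2, the two lying within the scatter of each other, and well above that of compound 1, as the step of a number 22.2 percentage points higher from compound 1 to compound 3 (beyond the scatter) shows. The other steps, a number 28.2 percentage points higher from compound 1 to compound 2 (beyond the scatter) and a number 6 percentage points lower from compound 2 to compound 3 (within the scatter), tell the same story: exchanging the phenyl on the carbonyl carbon for methyl or tert-butoxy raised inhibition by a modest amount, while methyl against tert-butoxy made no difference beyond the scatter.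

Compound 4 `NC(=O)c1c(NC(=O)c2ccc(Oc3ccccc3)cc2)sc2c1CCN(Cc1ccccc1)C2` differs from compound 3 as follows: benzyl in place of tert-butoxycarbonyl on an amine nitrogen in a ring. Within the data shown here, no measured pair carries a benzyl on that amine nitrogen, and none removes the carbonyl from it, so the measured steps give no direct guide to the direction. Among the measured compounds shown here, the only precedent, compound 1 with its phenyl on the carbonyl carbon, points to a lower number. An estimate for compound 4 is therefore 18%, within 0% to 45%; the expected step of a number 8.9 percentage points lower from compound 3 to compound 4 (within the scatter) would lie near the edge of the scatter.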

Compound 4, a percentage reported as inhibition, at one concentration (the size of the read-out at that concentration, not a potency): 23.6%
Estimate against measurement, compound 4: 5.6 percentage points below, and the stated range covers the measured number.
By their numbers in this assay, from the lowest: compound 1; then compounds 4, 3 and 2 (each within the scatter of the next).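

In this assay, the step of a number 3.3 percentage points lower from compound 3 to compound 4 (within the scatter) and the step of a number 9.3 percentage points lower from compound 2 to compound 4 (within the scatter) show that this amine nitrogen in a ring can carry benzyl, with no carbonyl on it, and still give a number in the range of the tert-butoxycarbonyl and acetyl compounds. The step of a number 18.9 percentage points higher from compound 1 to compound 4 (beyond the scatter) shows that the low number of compound 1 does not go with a phenyl ring in this substituent as such, since benzyl carries one too, and compound 1 alone of the four stands apart. Nothing available here accounts for that difference.

On these data alone, whether the unsubstituted amine, a longer chain such as phenethyl, or a carboxylic acid on this nitrogen's substituent would give a similar number remains open. How any of these compounds would read at other concentrations also remains open.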